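Repeating the 3-Hydroxyphenyl Swap in the Furan-3-yl Series

The source may report more compounds than this note shows. Statements on the series, on what has been measured and on what is new or still open speak of the compounds shown alone.

Compound 1 `Oc1ccccc1-c1cc(-c2ccsc2)cc(-c2ccccc2O)n1` gives 0% in an assay on isolated protein for inhibition of DNA topoisomerase 1 (Homo sapiens), with a stated time of 30 min, tested at 100 uM; on this read-out higher numbers stand for a stronger effect at the one concentration tested and lower numbers for a weaker effect. Compound 2 `Oc1cccc(-c2cc(-c3ccsc3)cc(-c3ccccc3O)n2)c1` differs by 3-hydroxyphenyl in place of 2-hydroxyphenyl on an aromatic carbon and gives 10.2% in this assay, a change of a number 10.2 percentage points higher from compound 1 to compound 2 (beyond the scatter). Compound 3 `Oc1ccccc1-c1cc(-c2ccoc2)cc(-c2ccccc2O)n1` differs from compound 1 by furan-3-yl in place of thiophen-3-yl on an aromatic carbon, a change of a number 1 percentage points higher from compound 1 to compound 3 (within the scatter). In this assay compound 3 gives 1%. Compound 4 `Oc1cccc(-c2cc(-c3ccoc3)cc(-c3ccccc3O)n2)c1`, not yet measured, differs from compound 3 by 3-hydroxyphenyl in place of 2-hydroxyphenyl on an aromatic carbon. This is the same kind of change as from compound 1 to compound 2, but the place differs: here the site is meta to a furan-3-yl group rather than meta to a thiophen-3-yl group. The step from compound 3 to compound 4 is expected to be a number 10 percentage points higher from compound 3 to compound 4 (within the scatter), resting on the earlier a number 10.2 percentage points higher from compound 1 to compound 2 (beyond the scatter) and on compound 3 at 1%. Compound 4 is therefore estimated at 11%, between 0% and 25%.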

Compound 4, a percentage reported as inhibition, at one concentration (the size of the read-out at that concentration, not a potency): 29.5%
Compound 4: middle estimate off by 18.5 percentage points, on the low side; measured number above the stated range.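

In this assay the 3-hydroxyphenyl swap keeps its direction on the furan-3-yl core, a number 28.5 percentage points higher from compound 3 to compound 4 (beyond the scatter), but not its size: the same change on two cores in this assay, a number 10.2 percentage points higher (beyond the scatter) from compound 1 to compound 2 and a number 28.5 percentage points higher (beyond the scatter) from compound 3 to compound 4, 18.3 percentage points apart, beyond the scatter of two such steps. The furan-3-yl swap likewise does not keep its size when the 3-hydroxyphenyl group is present, a number 19.3 percentage points higher from compound 2 to compound 4 (beyond the scatter): the same change on two cores in this assay, a number 1 percentage points higher (within the scatter) from compound 1 to compound 3 and a number 19.3 percentage points higher (beyond the scatter) from compound 2 to compound 4, 18.3 percentage points apart, beyond the scatter of two such steps. Both gaps rest on the same four compounds, so they form one observation that the two swaps do not add up, and they give neither a reason for it nor a rule for other cores.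

Open, going by these compounds, is whether a 4-hydroxyphenyl or an aminophenyl group at the same place gives a step of this size. Also open, on these data alone, is whether the remaining 2-hydroxyphenyl group tolerates the same swap, and how a pyridin-3-yl group compares with furan-3-yl.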